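Replacing phenethyl with 4-fluorophenyl on a sulfur

The compounds below may be only part of what the source reports. "The series", "measured", "known", "first", "only" and "open" are said of these compounds alone.

Two related compounds have been measured so far in a functional assay on A-375 cells (Homo sapiens) for inhibition, read by CCK-8 assay, with a stated time of 72 h, tested at 2 uM; on this read-out higher numbers stand for more inhibition of growth at the one concentration tested and lower numbers for less inhibition of growth. Compound 1 `CC(C)(C)c1ccc(SCc2ccc(C(=O)Nc3ccccc3N)cc2)cc1` gives 2.13%, while compound 2 `Nc1ccccc1NC(=O)c1ccc(CSCCc2ccccc2)cc1` gives 21.8%. Compound 2 is therefore the higher of the two, by a gap beyond the usual scatter, although neither compound stops growth to a large degree at this single concentration.

The next compound, compound 3 `Nc1ccccc1NC(=O)c1ccc(CSc2ccc(F)cc2)cc1`, has 4-fluorophenyl in place of phenethyl on a sulfur. Among the compounds with values here, no two measured compounds differ in one place only, so there is little to guide a prediction. The only lower reference point is compound 1 at 2.13%, so a result below compound 2 but above compound 1 seems most likely. In this assay, the expected step of a number 6.8 percentage points lower from compound 2 to compound 3 (within the scatter) is a modest fall, not clearly beyond the scatter. The estimate for compound 3 is 15%, with an expected range from 2% to 35%.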

Compound 3, percent growth inhibition at one concentration: 19.4%
Estimate against measurement, compound 3: 4.4 percentage points below; low and high end bracket the measured number.
By their numbers in this assay, from the lowest: compound 1; then compounds 3 and 2 (each within the scatter of the next).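

In this assay the change from phenethyl to 4-fluorophenyl on a sulfur gives a number 2.4 percentage points lower from compound 2 to compound 3 (within the scatter) and so does not separate these two groups at this position. Fluoro in place of tert-butyl on an aromatic carbon gives a number 17.3 percentage points higher from compound 1 to compound 3 (beyond the scatter) and is the first single-place change here with a step beyond the scatter, which shows that the group at that aromatic carbon can alter this read-out. Nothing measured here explains either step.

From the compounds shown here alone, it remains open what an amine or a carboxylic acid in place of fluoro would do, and whether a longer chain than phenethyl on the sulfur would move the result beyond the scatter. Going by these compounds, all of these readings also come from a single concentration, so how inhibition changes with dose is unknown.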